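From Phenoxy to Bromo on the Shared Core

This account rests on a few compounds, and the source may have more. Where it says the series, first, only, none or still open, it means among the compounds named here.

In a functional assay on the whole organism for inhibition, with Rattus norvegicus as the target (on this read-out higher numbers stand for an effect only at larger amounts of compound and lower numbers for an effect already at smaller amounts), compound 2 `CC(Cc1ccc(Cl)cc1)(Oc1ccc(Oc2ccccc2)cc1)C(=O)O` gives < 1 mg/kg as a limit and not a number. Compound 1 `COc1ccc(Cc2ccc(OC(C)(Cc3ccc(Cl)cc3)C(=O)O)cc2)cc1` likewise gives only a limit of < 10 mg/kg in this same read-out. Compound 3 `CC(Cc1ccc(Cl)cc1)(Oc1ccc(Br)cc1)C(=O)O` differs from compound 2 at one place: bromo in place of phenoxy on an aromatic carbon with bromo in place of phenoxy on an aromatic carbon. Among the measured compounds shown here, the one measured step that bears on this carbon is a step that the two limits leave unreadable from compound 1 to compound 2 and it offers no size to carry over. Any expectation is therefore loose and rests on the structural change alone, with a ring-bearing group giving way to a single atom. The expected change is an at least 2.5-fold higher number from compound 2 to compound 3 (0.39 log units; beyond the scatter) toward larger doses, and a further limit remains possible. In this assay compound 3 is expected at 2.5 mg/kg within a range of 0.5 mg/kg to 12 mg/kg by this estimate.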

Compound 3, dose for half-maximal effect: < 1 mg/kg
Compound 3 ended at the assay's limit (the forecaster's own chance of this, stated with the estimate: 45%); at least 2.5-fold (0.39 log units) between middle value and limit.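

In this assay, among the compounds shown here, compound 1, compound 2 and compound 3 all give limits and not numbers, so no step among them can be read. The compounds shown leave open whether phenoxy, bromo and 4-methoxybenzyl on this aromatic carbon differ in effect at all.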